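Aryl group exchange from compound 3 to compound 4

The compounds below may be only part of what the source reports. "The series", "measured", "known", "first", "only" and "open" are said of these compounds alone.

In a functional assay on HUVEC cells (Homo sapiens) for cytotoxicity (on this read-out higher numbers stand for an effect only at larger amounts of compound and lower numbers for an effect already at smaller amounts), compound 3 (`COC1=C(C)C(=O)/C(=C(O)/C=C/c2ccc(O)cc2)C(=O)C1(C)C`) gives 3.8 ug/mL. Compound 1 (`COC1=C(C)C(=O)/C(=C(O)/C=C/c2ccc(Br)cc2)C(=O)C1(C)C`) gives 3.6 ug/mL, and these two sit together at the upper end of the three numbers, with a 1.1-fold higher number from compound 1 to compound 3 (0.02 log units; within the scatter). Compound 2 (`COC1=C(C)C(=O)/C(=C(O)/C=C/c2ccccc2OC)C(=O)C1(C)C`) gives 1.7 ug/mL and stands apart from both, with a 2.1-fold lower number from compound 1 to compound 2 (0.33 log units; beyond the scatter) and a 2.2-fold higher number from compound 2 to compound 3 (0.35 log units; beyond the scatter).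

Compound 4 (`COC1=C(C)C(=O)/C(=C(O)/C=C/c2ccccc2C)C(=O)C1(C)C`) is the next compound to be read in this assay. The change from compound 3 is 2-methylphenyl in place of 4-hydroxyphenyl on a double-bonded chain carbon bound to a double-bonded chain carbon. It puts 2-methylphenyl in place of 4-hydroxyphenyl on a double-bonded chain carbon bound to a double-bonded chain carbon.

Within the data shown here, two measured steps bear on this change. The exchange between bromo and hydroxy gave a 1.1-fold higher number from compound 1 to compound 3 (0.02 log units; within the scatter), so removal of the hydroxy need not by itself move the number. Judged from the structures, the aryl group of compound 2 is the closest measured match to the entering 2-methylphenyl, and the modest 2.2-fold higher number from compound 2 to compound 3 (0.35 log units; beyond the scatter) is therefore the best guide, read in reverse. Among the measured compounds shown here, with only three measured compounds, this analogy remains weak.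

A modest shift towards a lower number is expected, near the edge of the scatter, and the estimated change is a 1.9-fold lower number from compound 3 to compound 4 (0.28 log units; within the scatter). The estimate for compound 4 is 2 ug/mL, with an expected range of 1 ug/mL to 4 ug/mL.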

Compound 4, concentration for half-maximal effect: 2.3 ug/mL
Beside the measured number, compound 4's estimate is 1.2-fold (0.06 log units) below it; the measured number falls inside the stated range.
By their numbers in this assay, from the lowest: compounds 2, 4, 1 and 3 (each within the scatter of the next, the first and the last beyond it).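

In this assay, 2-methylphenyl on a double-bonded chain carbon bound to a double-bonded chain carbon gives a 1.7-fold lower number from compound 3 to compound 4 (0.22 log units; within the scatter) and, in place of 4-bromophenyl, a 1.6-fold lower number from compound 1 to compound 4 (0.19 log units; within the scatter) at the same position, so neither exchange moves the number beyond the scatter. The change of methyl in place of methoxy on an aromatic carbon gives a 1.4-fold higher number from compound 2 to compound 4 (0.13 log units; within the scatter) and is also within the scatter, which leaves compound 4 unresolved from compound 2 as well as from compounds 1 and 3, even though compounds 2 and 3 stand apart with a 2.2-fold higher number from compound 2 to compound 3 (0.35 log units; beyond the scatter) as the step between them. The series now also shows that 4-hydroxyphenyl, with 1 hydrogen-bond donor and 1 hydrogen-bond acceptor, can give way to 2-methylphenyl, with 0 of each, without a step beyond the scatter. No measurement available here explains these steps.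

Going by these compounds, whether an amine or a carboxylic acid on the aromatic ring, or a longer chain in place of the methyl, would take the number outside this range remains open. On these data alone, the shared core is constant throughout, so what a change there would do also remains open.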